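The source may hold more compounds than are shown below. What is called first, only, known or untested is meant among the compounds shown, and "the series" means these compounds.

Compound 1 `Cc1ccc(CN2C(=O)S/C(=C\c3ccc(N(C)C)cc3)C2=O)cc1` gives 14.9% in a functional assay on the whole organism (plasma) with Mus musculus as the target, with a stated time of 15 days, at a dose of 10 mg/kg by the oral route; on this read-out higher numbers stand for a stronger effect at the one dose given and lower numbers for a weaker effect; compound 2 `COc1ccc(/C=C2\SC(=O)N(Cc3ccc(C)cc3)C2=O)cc1` gives 20.6%.

Compound 2 sits at the top of the two numbers, yet the pair lie within the scatter of each other, since a number 5.7 percentage points higher from compound 1 to compound 2 (within the scatter). Compound 3 `Cc1ccc(CN2C(=O)S/C(=C\c3ccc(Cl)cc3)C2=O)cc1` differs from compound 2 by chloro in place of methoxy on an aromatic carbon. Going by the values given here, no measured step touches chloro; the only step known, which also changed the same aromatic position, stayed within the scatter, so no shift beyond the scatter is expected in this assay. Compound 3 is therefore estimated at 18% (range 8% to 30%), an expected step of a number 2.6 percentage points lower from compound 2 to compound 3 (within the scatter).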

Compound 3, a percentage reported as activity, at one dose (the size of the read-out at that dose, not a potency): 18.7%
The estimate for compound 3 lay 0.7 percentage points below the measured number; low and high end bracket the measured number.
By their numbers in this assay, from the lowest: compounds 1, 3 and 2 (each within the scatter of the next).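

In this assay the change from 4-methoxyphenyl to 4-chlorophenyl gives a number 1.9 percentage points lower from compound 2 to compound 3 (within the scatter) and the change from dimethylamino to chloro gives a number 3.8 percentage points higher from compound 1 to compound 3 (within the scatter) so neither step separates the compounds. This aromatic carbon, para to a large group, has now carried three different groups, including chloro with its single heavy atom and no hydrogen-bond acceptor, with every step within the scatter. No measurement at hand explains these results. The compounds shown leave open whether a carboxylic acid on this aromatic carbon would give a step beyond the scatter, and whether a change elsewhere on the shared core would do so.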